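Chloro to Methoxyethoxy: Cytotoxicity Expected to Stay at the Limit

This account rests on a few compounds, and the source may have more. Where it says the series, first, only, none or still open, it means among the compounds named here.

Compound 1 `Fc1ccc(-c2nn3c(NC4CC4)cc(Cl)cc3c2-c2ccnc(NC3CCCC3)n2)cc1` — in an ADME assay on Vero cells (Chlorocebus sabaeus) for cytotoxicity (on this read-out lower numbers stand for higher toxicity in this test and higher numbers for lower toxicity in this test), compound 1 gives > 40000 nM, which is a limit of the assay rather than a number.
Compound 2 `Fc1ccc(-c2nn3c(Cl)cc(NC4CCCC4)cc3c2-c2ccnc(NC3CCCC3)n2)cc1` — in this assay compound 2 gives > 40000 nM, again a limit and not a number.

For the measured compounds named here, compound 2 therefore sits at the ceiling of what this test reports, as does the only other compound measured, (the limit of > 40000 nM in this assay, at which 2 of the 2 values shown sit). Going by the values given here, no step between measured compounds is available, so the size of the change toward the new compound cannot be read off from data. Compound 3 `COCCOc1cc(NC2CCCC2)cc2c(-c3ccnc(NC4CCCC4)n3)c(-c3ccc(F)cc3)nn12` differs from compound 2 in one place: 2-methoxyethoxy in place of chloro on an aromatic carbon. With both measured values resting at the limit, no shift beyond the usual scatter is expected in this assay for this exchange. Compound 3 is expected to give 40000 nM in this assay, within 20000 nM to 80000 nM. The step this implies, a number no higher from compound 2 to compound 3 (the limit leaves the size open), is expected to be none beyond the scatter, most likely reported again as a limit.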

Compound 3, half-maximal cytotoxic concentration: 32500 nM
The estimate for compound 3 lay 1.2-fold (0.09 log units) above the measured number; low and high end bracket the measured number.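

Placing 2-methoxyethoxy, with its 5 heavy atoms, on this aromatic carbon in place of chloro gives an at least 1.2-fold lower number from compound 2 to compound 3 (0.09 log units; that floor lies within the scatter) in this assay, so this position accepts a much larger group without a step that can be read as beyond the scatter. For the compounds shown here, of the three compounds, only compound 3 gives an actual number, 32500 nM, which places a measurable value for the first time. Compound 2 remains a limit and not a number, so the true step could be larger than this floor: the limit of > 40000 nM in this assay, at which 2 of the 3 values shown sit.

As far as these compounds go, it remains open whether the small drop in the number comes with the length of the chain or with its oxygen atoms. A plain methoxy, a longer ether chain or a chain ending in an amine at this position could help separate these two readings.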